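The source may report more compounds than this note shows. Statements on the series, on what has been measured and on what is new or still open speak of the compounds shown alone.

Measured compounds in a functional assay on isolated protein for antagonist activity at Oxoeicosanoid receptor 1 (Homo sapiens), read by fluorescence and calcium flux, with stated times of 2 min and 1 min; on this read-out higher numbers stand for weaker inhibition and lower numbers for stronger inhibition:
compound 1, `CCCCCCc1cc2ccccc2n1C(=O)CCCC(=O)O` — in this assay compound 1 gives 1550 nM
compound 2, `CCCCCCc1ccc2ccn(C(=O)CCCC(=O)O)c2c1` — in this assay compound 2 gives 18000 nM

Among the measured compounds shown here, compound 2 stands at the highest of the two numbers in this assay, that is, it is the weaker inhibitor of the pair; its only neighbour, compound 1, sits at a clearly lower number, and that gap lies beyond the scatter of repeat measurements. The two compounds share the core and the acid-bearing chain on the ring nitrogen, and differ in where the hexyl chain is attached, so nothing else in the series separates them.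

Compound 3, `O=C(O)CCCC(=O)n1ccc2ccccc21`, differs from compound 2 by hydrogen in place of hexyl on an aromatic carbon. For the measured compounds named here, no measured pair shows this change, so its size cannot be read from existing numbers. Going by the values given here, with the hexyl gone, compound 3 carries only the core and the acid chain; the expected step is toward a higher number, beyond the scatter, since the chain is the only carbon-rich substituent compound 2 has. Expected step: a 3.3-fold higher number from compound 2 to compound 3 (0.52 log units; beyond the scatter). Compound 3 is expected at 60000 nM, with a range from 15000 nM to 250000 nM, and a real chance that this assay reports only a limit.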

Compound 3, half-maximal inhibitory concentration: > 30000 nM
Compound 3 gave a limit, no number; the forecaster's own chance of this, stated with the estimate: 45%; the middle value lies beyond the limit too.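

In this assay, compound 3 stands at a limit and not at a number: the limit of > 30000 nM in this assay, at which 1 of the 3 values shown sits.

Hydrogen in place of hexyl on an aromatic carbon of the six-membered ring gives an at least 1.6-fold higher number from compound 2 to compound 3 (0.22 log units; that floor lies within the scatter), so this floor alone does not show that the hexyl chain counts for anything at the position it holds in compound 2. Among the compounds shown here, measured from the other hexyl placement, the same removal gives an at least 19-fold higher number from compound 1 to compound 3 (1.28 log units; beyond the scatter), which shows for the first time that a hexyl chain placed as in compound 1 carries a large share of the inhibition seen in this short series.

Going by these compounds, the true value of compound 3 stays unknown, so the contribution of hexyl at the compound 2 position cannot be sized and could be anywhere from within the scatter to large. Also open, on these data alone, is whether a butyl or octyl chain, a phenyl ring or an amine at either position would give a lower or a higher number than hexyl does.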